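Removing one methoxy group from a three-carbon-linked diphenol

The source may report more compounds than this note shows. Statements on the series, on what has been measured and on what is new or still open speak of the compounds shown alone.

Compound 1 `COc1ccc(CCCc2ccc(OC)c(OC)c2)c(O)c1` gives 97.9%
Compound 2 `COc1cccc(CCCc2cccc(O)c2)c1OC` gives 97.1%

Of the compounds shown here, two have so far been tested in an ADME assay on RAW264.7 cells (Mus musculus) for cytotoxicity, read by MTT assay, with a stated time of 24 h, tested at 1.25 ug/mL; a lower number here means a stronger effect, a higher number a weaker effect of the compound at the concentration tested. Compound 1 gives 97.9%, and compound 2 gives 97.1%. These two numbers lie within the usual scatter of each other, so compound 1 does not stand apart from compound 2; both leave the cells almost fully viable at this concentration. Among the measured compounds shown here, no pair of measured compounds differs in only one place, so no single measured step is available to lean on.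

Compound 3 `COc1ccc(CCCc2ccc(OC)cc2O)cc1` has not yet been measured. It differs from compound 1 in one place: hydrogen in place of methoxy on an aromatic carbon. Because compound 1 gives 97.9% and compound 2 gives 97.1% with no sign of strong cytotoxicity in either, the expected step of a number 1.9 percentage points lower from compound 1 to compound 3 (within the scatter) is none beyond the scatter. Compound 3 is therefore estimated at 96%, with a range from 86% to 104%.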

Compound 3, a percentage reported as activity, at one concentration (the size of the read-out at that concentration, not a potency): 98.9%
Estimate against measurement, compound 3: 2.9 percentage points below; low and high end bracket the measured number.
By their numbers in this assay, from the lowest: compounds 2, 1 and 3 (each within the scatter of the next).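

Hydrogen in place of methoxy on this aromatic carbon, ortho to a methoxy group and meta to a large group, is the first single-place change that can be read in this assay, and it gives a number 1 percentage points higher from compound 1 to compound 3 (within the scatter). At this concentration, then, the cells stay almost fully viable with or without this methoxy group, and the change shows no effect beyond the scatter. Nothing measured here accounts for this outcome, so it stands as a plain observation.

The compounds shown do not tell how an amine or a carboxylic acid on this aromatic carbon would fare, nor a longer chain in place of the linker of the shared core. Whether the cells stay as viable at higher concentrations of these compounds also remains open.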